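This account rests on a few compounds, and the source may have more. Where it says the series, first, only, none or still open, it means among the compounds named here.

Measured compounds:
- compound 1, `COc1cccc(-c2nn(-c3ccccc3)cc2-c2ccnc(NCCCNC(=O)c3cccc(C(F)(F)F)c3)c2)c1`: 3330 nM
- compound 2, `COc1cccc(-c2nn(-c3ccccc3)cc2-c2ccnc(NCCNC(=O)Nc3cccc(C(F)(F)F)c3)c2)c1`: 1880 nM

In a functional assay on COLO 205 cells (Homo sapiens) for antiproliferative activity (a higher number here means a weaker inhibitor of growth, a lower number a stronger inhibitor of growth), compound 1 gives 3330 nM, and compound 2 gives 1880 nM. These two numbers sit within the usual scatter of each other, so neither compound can be called the stronger. Compound 3, `COc1cccc(-c2nn(-c3ccccc3)cc2-c2ccnc(NCCCNC(=O)Nc3ccc(Cl)c(Cl)c3)c2)c1`, is not yet measured. It differs from compound 1 by (3,4-dichlorophenyl)amino in place of 3-(trifluoromethyl)phenyl on a carbonyl carbon. For the measured compounds named here, no measured pair shows this single change, so only an expectation is possible: a step from compound 1 to compound 3 of about a 1.5-fold lower number from compound 1 to compound 3 (0.18 log units; within the scatter), not beyond the scatter, is expected. Compound 3 is therefore estimated at 2200 nM, with a range from 700 nM to 7000 nM.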

Compound 3, concentration for 50% growth inhibition: 1870 nM
Estimate against measurement, compound 3: 1.2-fold (0.07 log units) above, within the range that was stated.
By their numbers in this assay, from the lowest: compounds 3, 2 and 1 (each within the scatter of the next).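

In this assay, for the compounds shown here, swapping 3-(trifluoromethyl)phenyl for (3,4-dichlorophenyl)amino on the carbonyl carbon gives a 1.8-fold lower number from compound 1 to compound 3 (0.25 log units; within the scatter), the first single-change comparison here. This exchange therefore has no effect that can be told apart from assay noise, although it adds a hydrogen-bond donor and replaces three fluorines with two chlorines. Nothing available explains this outcome.

The added amino nitrogen and the changed ring substituents cannot be judged separately, since they arrive together. From the compounds shown here alone, whether a longer chain or a terminal carboxylic acid would shift growth inhibition also remains open.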